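Antiproliferative read-out at one concentration in a small amide series

A few compounds are considered here, and "the series" means these few. Any claim that something is new, unique, unknown or untested is made for them only; others in the source may bear on it.

Measured so far:
- compound 1 `CNC(=O)N1CCCc2ccc(NC(=O)c3ccc(-c4cc[nH]n4)cc3)cc21`: 99.1%
- compound 2 `CNC(=O)N1CCCc2ccc(NC(=O)c3cccc(-c4ccn(C)n4)c3)cc21`: 99.5%

Both compounds carry the same core and differ only in the aryl amide part. In a functional assay on MV4-11 cells (Homo sapiens) for antiproliferative activity, with a stated time of 6 days, tested at 6.25 uM (on this read-out lower numbers stand for a weaker effect and higher numbers for a stronger effect at the one concentration tested), compound 1 gives 99.1%, and in this assay compound 2 gives 99.5%. Compound 2 carries the higher of the two numbers, but the gap to compound 1 lies within the usual scatter, so the two are not separable on this read-out; both sit close to full inhibition at the concentration tested.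

Compound 3 `CNC(=O)N1CCCc2ccc(NC(=O)c3cccc(-c4ccccc4)c3)cc21` has not yet been measured in this assay. It differs from compound 2 in one place: phenyl in place of 1-methyl-1H-pyrazol-3-yl on an aromatic carbon. Within the data shown here, no measured pair shows this change, so the size of its effect is unknown. Given that compound 2 lies near the top of the scale, a step upward is not possible beyond the scatter; the expectation is a step of a number 9.5 percentage points lower from compound 2 to compound 3 (within the scatter), downward or none beyond the scatter. Compound 3 is therefore estimated at 90%, with a range from 55% to 100%.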

Compound 3, a percentage reported as inhibition, at one concentration (the size of the read-out at that concentration, not a potency): 1.39%
Compound 3: middle estimate off by 88.6 percentage points, on the high side; measured number outside the range, below it.
By their numbers in this assay, from the lowest: compound 3; then compounds 1 and 2 (each within the scatter of the next).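

In this assay the group on this aromatic carbon decides the read-out at the one concentration tested: with phenyl in place of 1-methyl-1H-pyrazol-3-yl, there is a number 98.1 percentage points lower from compound 2 to compound 3 (beyond the scatter), so this position is far from tolerant of every aromatic ring. Both groups hold 6 heavy atoms and neither has a net charge, so matching these counts does not preserve the effect; the change replaces a five-membered aromatic ring with 2 hetero atoms by a six-membered ring of carbon only. No measurement available here explains the step.

The compounds shown leave open whether a pyridyl ring, with one ring nitrogen, keeps the high read-out at this position or follows phenyl. They also leave open whether a phenyl ring carrying an amine or a carboxylic acid recovers any of the lost effect.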